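The source may hold more compounds than are shown below. What is called first, only, known or untested is meant among the compounds shown, and "the series" means these compounds.

Three related compounds have been tested so far in a functional assay on KYSE-450 cells (Homo sapiens) for inhibition, read by CCK-8 assay, with a stated time of 48 h (on this read-out lower numbers stand for stronger inhibition and higher numbers for weaker inhibition), and a fourth is waiting for its result. In this assay, compound 1 `COc1ccc(CN(C(=O)CSC(=S)N2CCN(Cc3ccc(C(C)(C)C)cc3)CC2)c2cc(OC)c(OC)c(OC)c2)cc1` gives 2140 nM. Compound 2 `COc1ccc(CN(C(=O)CSC(=S)N2CCc3cc(Br)ccc32)c2cc(OC)c(OC)c(OC)c2)cc1` reads > 20000 nM, which is a limit of the assay and not a number. Compound 3 `COc1cc(N(Cc2ccc(Br)cc2)C(=O)CSC(=S)N2CCN(C(=O)OC(C)(C)C)CC2)cc(OC)c1OC` gives 10700 nM. That is the higher of the two actual numbers, so compound 3 is clearly weaker than compound 1, by more than the usual scatter of repeat measurements.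

The untested compound 4 `COc1ccc(CN(C(=O)CSC(=S)N2CCN(C(=O)OC(C)(C)C)CC2)c2cc(OC)c(OC)c(OC)c2)cc1[N+](=O)[O-]` keeps most of compound 3 and changes one part: a 4-methoxy-3-nitrophenyl takes the place of a 4-bromophenyl on a saturated chain carbon bound to an amide-type nitrogen. Put another way, 4-bromobenzyl becomes 4-methoxy-3-nitrobenzyl, and the count of the change reads (4-methoxy-3-nitrophenyl in place of 4-bromophenyl on a saturated chain carbon bound to an amide-type nitrogen).

Going by the values given here, no two measured compounds differ in only one place, so the data do not show what this swap does. The best starting point is therefore compound 3 itself, at 10700 nM, with no shift beyond the scatter expected in this assay. The expected change is a 1.2-fold lower number from compound 3 to compound 4 (0.08 log units; within the scatter). The estimated value for compound 4 is 9000 nM, with an expected range from 3000 nM to 20000 nM.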

Compound 4, half-maximal inhibitory concentration: 810 nM
Compound 4: the middle estimate sits 11-fold (1.05 log units) above what was measured, outside the stated range (below it).
By their numbers in this assay, from the lowest: compound 4; then compound 1; then compound 3. At a limit, above all of these: compound 2.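

In this assay, 4-methoxy-3-nitrophenyl in place of 4-bromophenyl on a saturated chain carbon bound to an amide-type nitrogen gives a 13-fold lower number from compound 3 to compound 4 (1.12 log units; beyond the scatter). Going by these compounds alone, this is the first pair here that differs in only one place, so it is the first direct evidence that this position can strongly change the read-out, and that the large shift comes from this single swap and not from elsewhere in the molecule. The swap removes a bromine and brings in a methoxy and a nitro group together, so this one pair cannot separate their contributions, and nothing shown gives a cause for the shift.

As far as these compounds go, it remains open how much of the gain depends on the nitro group, which could be tested by putting an amine or a nitrile in its place while keeping the rest of compound 4 unchanged. From the compounds shown here alone, it is also open whether the same swap would lower the number to a similar extent on the core of compound 1, which carries a different group at the far end of the molecule.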